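The source may report more compounds than this note shows. Statements on the series, on what has been measured and on what is new or still open speak of the compounds shown alone.

Compound 2, `CCC(/C=C(\COC(C)=O)C(=O)c1ccccc1)CC`, and compound 1, `O=C(/C(=C/c1ccc(Cl)cc1Cl)CCl)c1ccccc1`, share the same core and were both tested in a functional assay on HeLa cells (Homo sapiens) for inhibition, read by sulforhodamine B assay, with a stated time of 48 h; a lower number here means a stronger inhibitor of growth, a higher number a weaker inhibitor of growth. In this assay compound 2 gives 50000 nM, the higher of the two numbers. Compound 1 gives 15000 nM in this assay, and the gap between these two values lies beyond the usual scatter of the method. Compound 3, `CC(=O)OC/C(=C\c1ccc(F)cc1)C(=O)c1ccccc1`, has not yet been measured. Its difference from compound 2 is 4-fluorophenyl in place of pentan-3-yl on a double-bonded chain carbon bound to a double-bonded chain carbon. For the measured compounds named here, no measured pair shows this exact swap, so any expectation rests on compound 1, which also carries an aromatic ring on a double-bonded chain carbon and gives 15000 nM, a lower number than compound 2. The estimated step is a 2.5-fold lower number from compound 2 to compound 3 (0.40 log units; beyond the scatter), a moderate move toward a lower number. Compound 3 is therefore expected to give 20000 nM in this assay, with a likely range from 7000 nM to 60000 nM.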

Compound 3, concentration for 50% growth inhibition: 25000 nM
Beside the measured number, compound 3's estimate is 1.3-fold (0.10 log units) below it; low and high end bracket the measured number.
By their numbers in this assay, from the lowest: compounds 1, 3 and 2 (each within the scatter of the next, the first and the last beyond it).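

In this assay, for the compounds shown here, putting 4-fluorophenyl in place of pentan-3-yl on a double-bonded chain carbon bound to a double-bonded chain carbon gives a 2.0-fold lower number from compound 2 to compound 3 (0.30 log units; within the scatter) and is the first direct reading of a change at this position. The step does not separate the open branched chain from the fluorinated aromatic ring, so an aromatic ring is not needed here for a number in this range, at least for this pair. Nothing shown explains the size of this step or measures any property of the two groups. The compounds shown leave open whether the fluorine matters, which a plain phenyl ring at this carbon would test, and whether an amine or a longer chain there would give a clearly different number. Compound 1 differs from compound 3 in more than one place, so the gap between them cannot be assigned to any single change.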